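The source may report more compounds than this note shows. Statements on the series, on what has been measured and on what is new or still open speak of the compounds shown alone.

Compound 1 `CCN(CC)CC(=O)Nc1ccc(Nc2cc(Cl)nc(-c3ccc(OC)cc3)n2)cc1` gives 5810 nM in a functional assay on Ishikawa cells (Homo sapiens) for antiproliferative activity, read by MTT assay, with a stated time of 48 h; on this read-out lower numbers stand for stronger inhibition and higher numbers for weaker inhibition.
Compound 2 `COc1ccc(-c2nc(Cl)c(-c3ccccc3)c(Nc3ccc(NC(=O)CN4CCCC4)cc3)n2)cc1` gives > 40000 nM, which is a limit of this assay.
Compound 3 `COc1ccc(-c2nc(Cl)cc(Nc3ccc(NC(=O)CN(C)C)cc3)n2)cc1` gives > 40000 nM, again a limit of this assay.

Compound 3 thus stands at the limit of this assay, with no number of its own; the limit of > 40000 nM in this assay, at which 2 of the 3 values shown sit, shows that compound 2 sits at that same limit, so compound 1 alone carries a measured number. The move to compound 4 `COc1ccc(-c2nc(Cl)cc(Nc3ccc(NC(=O)CN4CCCC4)cc3)n2)cc1` is pyrrolidin-1-yl in place of dimethylamino on a saturated chain carbon bound to a carbonyl carbon. Within the data shown here, the only measured step at this place, an at least 6.8-fold higher number from compound 1 to compound 3 (0.83 log units; beyond the scatter), ran from a measured number up to the limit, so the choice of amine on the saturated chain carbon bound to the carbonyl carbon matters here, with diethylamino giving the lower number. Pyrrolidin-1-yl is a third variant at the same place; compound 2, which also carries pyrrolidin-1-yl but differs from compound 4 in more than one place, sits at the limit. Compound 4 is therefore expected to stay near the limit, with the step of an at least 1.3-fold lower number from compound 3 to compound 4 (0.12 log units; that floor lies within the scatter) small and a lower number only a modest possibility. The estimate for compound 4 is 30000 nM, ranging from 8000 nM to 60000 nM.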

Compound 4, half-maximal inhibitory concentration: 18400 nM
Beside the measured number, compound 4's estimate is 1.6-fold (0.21 log units) above it, and the stated range covers the measured number.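

In this assay, the amine on the saturated chain carbon bound to a carbonyl carbon now shows three distinct outcomes: pyrrolidin-1-yl brings the number down from the limit held by dimethylamino (an at least 2.1-fold lower number from compound 3 to compound 4 (0.33 log units; beyond the scatter)), but it does not match diethylamino (a 3.2-fold higher number from compound 1 to compound 4 (0.50 log units; beyond the scatter)). The phenyl on an aromatic carbon can now be read as well, since with pyrrolidin-1-yl held in place, the compound with hydrogen in place of phenyl has the lower number (an at least 2.1-fold lower number from compound 2 to compound 4 (0.33 log units; beyond the scatter)). Both of these steps start from a limit and so give only a floor: the limit of > 40000 nM in this assay, at which 2 of the 4 values shown sit.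

Going by these compounds, how a piperidin-1-yl or morpholin-4-yl group would rank against diethylamino at this place stays open, as does the effect of a longer chain between the carbonyl and the amine. The compounds also leave open whether a methyl group on that aromatic carbon would behave like hydrogen or like phenyl.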